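The source may report more compounds than this note shows. Statements on the series, on what has been measured and on what is new or still open speak of the compounds shown alone.

Measured so far:
compound 1, `NC(=O)c1cc(-c2ccccc2)cc2c(C3CCN(S(=O)(=O)CCCN4CCCC4)CC3)c[nH]c12`: 160 nm/s
compound 2, `NC(=O)c1cc(-c2ccccc2)cc2c(C3CCS(=O)(=O)CC3)c[nH]c12`: 277 nm/s

In an ADME assay for permeability, using PAMPA (a higher number here means that the compound crosses the layer faster, a lower number that the compound crosses the layer more slowly), compound 1 carries the smaller of the two numbers shown, yet compound 2 lies within the usual scatter of it, so the two cannot be told apart. Compound 3, `CCN(CC)CCCS(=O)(=O)N1CCC(c2c[nH]c3c(C(N)=O)cc(-c4ccccc4)cc23)CC1`, has not been measured. It differs from compound 1 in one place: diethylamino in place of pyrrolidin-1-yl on a saturated chain carbon, three bonds along the chain from a sulfonyl sulfur. The leaving and entering groups match in what is counted, so in this assay the expected step is a 1.1-fold higher number from compound 1 to compound 3 (0.03 log units; within the scatter), staying within the scatter. Compound 3 is therefore estimated at 170 nm/s, with a range from 85 nm/s to 340 nm/s.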

Compound 3, apparent permeability: 200 nm/s
Estimate against measurement, compound 3: 1.2-fold (0.07 log units) below; measured number inside the range.
By their numbers in this assay, from the lowest: compounds 1, 3 and 2 (each within the scatter of the next).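

In this assay, replacing pyrrolidin-1-yl with diethylamino on a saturated chain carbon, three bonds along the chain from a sulfonyl sulfur, gives a 1.3-fold higher number from compound 1 to compound 3 (0.10 log units; within the scatter) for this single change. At this position, then, opening the ring while keeping the same count of heavy atoms leaves no difference that can be told from repeat scatter. Nothing available here offers an explanation for this result. Still open, as far as these compounds go, is whether a piperidine or morpholine ring, a dimethylamino group or a carboxylic acid at this chain end would also stay this close. From the compounds shown here alone, a shorter or longer chain is equally open.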